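This account rests on a few compounds, and the source may have more. Where it says the series, first, only, none or still open, it means among the compounds named here.

For the measured compounds named here, in a functional assay on MKN-74 cells (Homo sapiens) for antiproliferative activity, with a stated time of 24 h (on this read-out higher numbers stand for weaker inhibition and lower numbers for stronger inhibition), compound 2, `NC(=O)c1c(NC(=O)c2ccccc2Cl)sc2c1CCN(C(=S)Nc1ccccc1C(F)(F)F)C2`, gives 1870 nM, the lower of the two values measured so far; compound 1, `NC(=O)c1c(NC(=O)c2ccccc2Cl)sc2c1CCN(Cc1ccccc1)C2`, gives 14500 nM, a gap that lies beyond the usual scatter. Compound 3, `NC(=O)c1c(NC(=O)c2ccccc2Cl)sc2c1CCN(C(=S)Nc1cccnc1)C2`, has not yet been tested; it differs from compound 2 in one place: pyridin-3-yl in place of 2-(trifluoromethyl)phenyl on an amide-type nitrogen. Going by the values given here, no measured pair reflects this change, so the estimate rests on compound 2 alone. The expected step from compound 2 to compound 3 in this assay is a 2.4-fold higher number from compound 2 to compound 3 (0.38 log units; beyond the scatter), a moderate move toward weaker inhibition. Compound 3 is therefore expected to give about 4500 nM, within 1500 nM to 13000 nM.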

Compound 3, half-maximal inhibitory concentration: 38600 nM
For compound 3 the middle estimate is 8.6-fold (0.93 log units) below the measured one; the whole stated range lies below it.
By their numbers in this assay, from the lowest: compound 2; then compound 1; then compound 3.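

In this assay, pyridin-3-yl in place of 2-(trifluoromethyl)phenyl on the amide-type nitrogen brings a 21-fold higher number from compound 2 to compound 3 (1.31 log units; beyond the scatter) and shows that the result depends strongly on this group, something compound 1 and compound 2 could not show. The thiocarbonyl-bearing group alone does not ensure the lower number, since the change on the ring amine nitrogen brings a 2.7-fold higher number from compound 1 to compound 3 (0.43 log units; beyond the scatter) for this pyridine-bearing compound. No evidence is available to explain the step. The compounds shown leave open whether the trifluoromethyl group or the ring nitrogen drives the change, and how a plain phenyl or a pyridin-2-yl group would read.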